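Lengthening the Sulfonyl Chain of Compound 2

The source may report more compounds than this note shows. Statements on the series, on what has been measured and on what is new or still open speak of the compounds shown alone.

- compound 1 `NS(=O)(=O)c1ccc(S(=O)(=O)CCCO)c(F)c1`: 6600 ug/mL
- compound 2 `COC(=O)c1cc(S(N)(=O)=O)ccc1S(=O)(=O)CCO`: 33400 ug/mL

For the measured compounds named here, in a physicochemical assay for solubility, at pH 7.4 (on this read-out higher numbers stand for higher solubility and lower numbers for lower solubility), compound 2 gives 33400 ug/mL, the higher of the two numbers so far. Compound 1 gives 6600 ug/mL, and that gap lies beyond the usual scatter of the measurement.

Compound 3 `COC(=O)c1cc(S(N)(=O)=O)ccc1S(=O)(=O)CCCO` has not yet been measured. It departs from compound 2 by hydroxymethyl in place of hydroxy on a saturated chain carbon, two bonds along the chain from a sulfonyl sulfur. Read one bond further out, this is (2-hydroxyethyl)sulfonyl to (3-hydroxypropyl)sulfonyl.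

Going by the values given here, no measured pair isolates this change, so its size in this assay rests on thin evidence. Among the compounds with values here, compound 1, the only measured compound with a (3-hydroxypropyl)sulfonyl group, stands at 6600 ug/mL, and this is the sole pointer towards a lower number. A modest fall near the edge of the scatter is therefore expected, and the estimated step is a 2.2-fold lower number from compound 2 to compound 3 (0.35 log units; beyond the scatter). The expected value for compound 3 is 15000 ug/mL, with an estimated range of 6000 ug/mL to 36000 ug/mL.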

Compound 3, solubility: 14000 ug/mL
Beside the measured number, compound 3's estimate is 1.1-fold (0.03 log units) above it, and the stated range covers the measured number.
By their numbers in this assay, from the lowest: compound 1; then compound 3; then compound 2.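

In this assay, the change from (2-hydroxyethyl)sulfonyl to (3-hydroxypropyl)sulfonyl now has a measured size with the methoxycarbonyl group held in place: a 2.4-fold lower number from compound 2 to compound 3 (0.38 log units; beyond the scatter). With the (3-hydroxypropyl)sulfonyl group held in place instead, the change from fluoro to methoxycarbonyl on an aromatic carbon can also be read, as a 2.1-fold higher number from compound 1 to compound 3 (0.33 log units; beyond the scatter), so the gap between compound 1 and compound 2, which differ in two places, now resolves into two single changes that run in opposite directions. Nothing in the data available here accounts for either step.

Each of these changes rests on a single pair, so the compounds shown leave open whether the chain step would have the same size with fluoro on the aromatic carbon, or whether the aromatic change would have the same size with the (2-hydroxyethyl)sulfonyl group. They also leave open where a longer chain would fall in this assay, and whether an amine or a carboxylic acid in place of the hydroxy would give a higher or a lower number.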